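Aryl variation on the ring amide nitrogen: compound 3 outlook

This account rests on a few compounds, and the source may have more. Where it says the series, first, only, none or still open, it means among the compounds named here.

Measured so far:
compound 1, `O=C1c2cc(COc3ccccc3)nn2CCN1c1cccc(F)c1`, 81%
compound 2, `COc1ccc(N2CCn3nc(COc4ccccc4)cc3C2=O)cc1`, 58%

Within the data shown here, in a functional assay on HEK293 cells for positive allosteric modulation of metabotropic glutamate receptor 5 (Homo sapiens), read by calcium flux (a higher number here means a larger maximal response, a lower number a smaller maximal response), compound 2 stands lowest of the two numbers; the only measured step, a number 23 percentage points lower from compound 1 to compound 2 (beyond the scatter), is modest but beyond the scatter. Compound 3, `O=C1c2cc(COc3ccccc3)nn2CCN1c1ccccn1`, differs from compound 2 by pyridin-2-yl in place of 4-methoxyphenyl on an amide-type nitrogen in a ring. Among the measured compounds shown here, no measured step concerns pyridin-2-yl, so the one step above gives only the rough scale of aryl swaps here. Given that compound 2 gives 58%, compound 3 is expected to rise, a number 12 percentage points higher from compound 2 to compound 3 (beyond the scatter), to an estimated 70% with a range of 50% to 90%.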

Compound 3, largest response reached (Emax), in percent of the reference or control that the assay uses: 69%
For compound 3 the middle estimate is 1 percentage points above the measured one, within the range that was stated.
By their numbers in this assay, from the lowest: compound 2; then compound 3; then compound 1.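

In this assay, pyridin-2-yl on the amide-type nitrogen gives a number 11 percentage points higher from compound 2 to compound 3 (beyond the scatter) for the swap from 4-methoxyphenyl, and a number 12 percentage points lower from compound 1 to compound 3 (beyond the scatter) for the swap from 3-fluorophenyl. This position therefore accepts an aromatic ring with a hetero atom, and the response with it lies between those of the two substituted phenyl groups. Nothing available explains these differences.

Open, on these data alone, is whether pyridin-3-yl or pyridin-4-yl on the same nitrogen would differ from pyridin-2-yl. Also open, as far as these compounds go, is how unsubstituted phenyl or a saturated cyclohexyl group would compare with 3-fluorophenyl.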